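This account rests on a few compounds, and the source may have more. Where it says the series, first, only, none or still open, it means among the compounds named here.

Compound 1, `CC1=CC[C@H](C(C)(C)NC(=S)N/N=C/c2ccc(O)cc2)CC1`, in a functional assay on K562 cells (Homo sapiens) for inhibition, read by sulforhodamine B assay, with a stated time of 48 h (on this read-out higher numbers stand for weaker inhibition of growth and lower numbers for stronger inhibition of growth), gives > 100000 nM, which is a limit of the assay rather than a number.
Compound 2, `CC1=CC[C@H](C(C)(C)NC(=S)N/N=C(\C)c2ccccc2)CC1`, in this assay gives > 100000 nM, likewise a limit of the assay.

Among the measured compounds shown here, compound 2 therefore stands only at a limit in this assay, and the one other value shown is a limit as well: the limit of > 100000 nM in this assay, at which 2 of the 2 values shown sit. For the measured compounds named here, neither measured compound has given a number, so no step between measured compounds can be counted here, and nothing shows how a change on the aromatic ring moves the read-out.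

Compound 3, `CC1=CC[C@H](C(C)(C)NC(=S)N/N=C(\C)c2ccc([N+](=O)[O-])cc2)CC1`, has not yet been measured in this assay. It differs from compound 2 in one place: nitro in place of hydrogen on an aromatic carbon. With both measured compounds sitting at the limit, the expectation for this change is no step beyond the scatter, in either direction. The estimate for compound 3 in this assay is 100000 nM, with a range from 30000 nM to 300000 nM, and this expected value means a step of a number no higher from compound 2 to compound 3 (the limit leaves the size open). Most likely compound 3 will again be reported only as a limit.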

Compound 3, concentration for total growth inhibition: > 100000 nM
Compound 3 ended at the assay's limit; the forecaster's own chance of this, stated with the estimate: 75%; the middle value sits exactly at the limit.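

Compound 2 and compound 3 both stand only at a limit in this assay, and no step can be read for nitro in place of hydrogen on an aromatic carbon. The compounds shown leave open how strongly any of them inhibits growth, and whether a change on the aromatic ring moves the read-out at all: the limit of > 100000 nM in this assay, at which 3 of the 3 values shown sit.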